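The source may hold more compounds than are shown below. What is called first, only, known or untested is meant among the compounds shown, and "the series" means these compounds.

Measured compounds:
Compound 1, `CCC(=O)Nc1ccc(-c2nc3cc(C(F)(F)F)ccc3[nH]2)cc1`: 100000 nM
Compound 2, `CC(=O)Nc1ccc(-c2nc3cc(C(F)(F)F)ccc3[nH]2)cc1`: 53000 nM

The two compounds were tested in an ADME assay on BHK cells (Mesocricetus auratus) for cytotoxicity, read by MTT assay, with a stated time of 96 h; on this read-out lower numbers stand for higher toxicity in this test and higher numbers for lower toxicity in this test. Compound 1 gives 100000 nM and compound 2 gives 53000 nM. Among the compounds with values here, compound 2 holds the lowest of the two numbers, but the only measured step, a 1.9-fold lower number from compound 1 to compound 2 (0.28 log units; within the scatter), lies within the scatter, so the two compounds are not separated in this assay.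

Compound 3, `Fc1ccc(-c2nc3cc(C(F)(F)F)ccc3[nH]2)cc1`, has not yet been measured. It differs from compound 2 in one place: fluoro in place of acetamido on an aromatic carbon. Within the data shown here, no measured step bears directly on this exchange; the one known step concerns only the chain on the carbonyl carbon and was itself within the scatter. There is thus no basis in the data for expecting a step beyond the scatter in this assay, in either direction.

Compound 3 is therefore expected to give about 60000 nM in this assay, with a range from 20000 nM to 150000 nM. The estimated step from compound 2 is a 1.1-fold higher number from compound 2 to compound 3 (0.05 log units; within the scatter), which is expected to stay within the scatter.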

Compound 3, half-maximal cytotoxic concentration: 25000 nM
Compound 3: the middle estimate sits 2.4-fold (0.38 log units) above what was measured; low and high end bracket the measured number.
By their numbers in this assay, from the lowest: compound 3; then compounds 2 and 1 (each within the scatter of the next).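

In this assay the earlier pair had shown only that a change within the amide chain stays within the scatter, and it said nothing about replacing the amide itself on this aromatic carbon, para to a large group. Fluoro in place of acetamido moves the number beyond the scatter (a 2.1-fold lower number from compound 2 to compound 3 (0.33 log units; beyond the scatter)), as does fluoro in place of propanoylamino (a 4.0-fold lower number from compound 1 to compound 3 (0.60 log units; beyond the scatter)), so compound 3 stands apart from both amides, with the lowest number of the three and thus the highest toxicity in this test, although both steps are modest. Nothing at hand accounts for this shift.

The compounds shown leave open whether the lower number goes with the arrival of fluoro or with the loss of the amide, a question that plain hydrogen or a chloro group on this carbon could help to separate. They also leave open how an amine, a carboxylic acid or a longer acyl chain on the amide nitrogen would read at this place.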